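The source may hold more compounds than are shown below. What is called first, only, known or untested is meant among the compounds shown, and "the series" means these compounds.

The measured compounds:
- Compound 1, `CC(C)Oc1nc(N)nc2ncc(-c3ccc(C#N)cc3)nc12`, in a functional assay on cells (T-cell, Homo sapiens) for inhibition (a lower number here means a stronger inhibitor, a higher number a weaker inhibitor), gives only a limit, > 10000 nM.
- Compound 2, `COc1ccc(-c2cnc3nc(N)nc(N4CCN(Cc5ccccc5F)CC4)c3n2)cc1OC`, in this assay gives 700 nM.
- Compound 3, `CCOc1nc(N)nc2ncc(-c3cccc(OC)c3)nc12`, in this assay gives 8300 nM.

Of the two compounds that give an actual number, compound 2 has the lower one and is therefore the stronger inhibitor of that pair; compound 3 stands at a number that is beyond the usual scatter of repeated measurements. Compound 1 contributes no number, only the limit (the limit of > 10000 nM in this assay, at which 1 of the 3 values shown sits), so it cannot be placed relative to the others beyond being weak.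

Compound 4, `COc1ccc(-c2cnc3nc(N)nc(N4CCN(C(=O)COc5ccc(Cl)cc5)CC4)c3n2)cc1OC`, has not yet been measured. It differs from compound 2 in a single place: ((4-chlorophenoxy)methyl)carbonyl in place of 2-fluorobenzyl on an amine nitrogen in a ring. The 2-fluorobenzyl group leaves and the ((4-chlorophenoxy)methyl)carbonyl group enters on an amine nitrogen in a ring, on the part of the molecule that the three measured compounds do not share.

Among the measured compounds shown here, no pair of measured compounds shows a change of this kind, so the size and direction of the step have to be guessed from compound 2 alone. A step of modest size toward a higher number is expected, a 2.1-fold higher number from compound 2 to compound 4 (0.33 log units; beyond the scatter), though a step within the scatter would not be surprising. For compound 4 the estimate in this assay is 1500 nM, with a range from 300 nM to 6000 nM.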

Compound 4, half-maximal inhibitory concentration: 0.5 nM
Beside the measured number, compound 4's estimate is 3000-fold (3.48 log units) above it, outside the stated range (below it).
By their numbers in this assay, from the lowest: compound 4; then compound 2; then compound 3. At a limit, above all of these: compound 1.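

The group on the amine nitrogen in a ring of the six-membered ring with 2 nitrogen can move the number in this assay enormously: putting ((4-chlorophenoxy)methyl)carbonyl in place of 2-fluorobenzyl gives a 1400-fold lower number from compound 2 to compound 4 (3.15 log units; beyond the scatter), with the rest of the molecule unchanged. The earlier compounds shown here could not show this, as no two of them differed in one place, so compound 2 alone gave no sign of how much this position matters. The swap brings in a carbonyl and a chlorine together and also changes what links the aromatic ring to the nitrogen, and nothing measured here shows which of these parts accounts for the step.

From the compounds shown here alone, it remains open whether a smaller group on that nitrogen, such as a plain acetyl group, would keep any of this gain, or whether the 4-chlorophenoxy part is needed for it. Also open, going by these compounds, is how a ((4-chlorophenoxy)propyl)carbonyl group, with its longer chain, or a bromine in place of the chlorine would read in this assay on the same core.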